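A few compounds are considered here, and "the series" means these few. Any claim that something is new, unique, unknown or untested is made for them only; others in the source may bear on it.

Compound 2 `C=CC(=O)Nc1cc(Nc2ncc(Cl)c(Nc3ccccc3NC(=O)C(C)(C)C)n2)c(OC)cc1N1CCN(C)CC1` is the weaker of the two compounds measured in a functional assay on NCI-H3122 cells (Homo sapiens) for inhibition, read by CellTiter-Glo, with a stated time of 72 h; on this read-out lower numbers stand for stronger inhibition of growth and higher numbers for weaker inhibition of growth. In this assay compound 2 gives 6500 nM, whereas compound 1 `C=CC(=O)Nc1cc(Nc2ncc(Cl)c(Nc3ccc(F)c(Cl)c3)n2)c(OC)cc1N1CCN(C)CC1` gives 300 nM, a gap that lies well beyond the usual scatter of repeated measurements. Compound 3 `C=CC(=O)Nc1cc(Nc2ncc(Cl)c(Nc3ccccc3S(=O)(=O)N(C)C)n2)c(OC)cc1N1CCN(C)CC1` differs from compound 2 in a single place: dimethylsulfamoyl in place of ((tert-butyl)carbonyl)amino on an aromatic carbon. For the measured compounds named here, no measured pair shows this particular exchange, so the size of the step cannot be read from existing numbers and must be estimated. Compound 3 keeps the shared core of compound 1, which gives 300 nM, and that lower number marks the strongest inhibition seen so far among these compounds. Compound 3 is therefore expected to give about 1200 nM, with a likely range from 250 nM to 6000 nM. That expectation means a step of a 5.4-fold lower number from compound 2 to compound 3 (0.73 log units; beyond the scatter), estimated to run toward stronger inhibition and beyond the scatter.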

Compound 3, concentration for 50% growth inhibition: 11 nM
Beside the measured number, compound 3's estimate is 110-fold (2.04 log units) above it, and the stated range ends above it.
By their numbers in this assay, from the lowest: compound 3; then compound 1; then compound 2.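

In this assay the group on this aromatic carbon matters far more than compounds 1 and 2 alone could show: with the rest of the molecule unchanged, dimethylsulfamoyl in place of ((tert-butyl)carbonyl)amino gives a 590-fold lower number from compound 2 to compound 3 (2.77 log units; beyond the scatter) and turns the weakest compound into the strongest. The substituted ring of compound 2 therefore need not be a poor choice, since 2-(dimethylsulfamoyl)phenyl in place of 3-chloro-4-fluorophenyl also gives a 27-fold lower number from compound 1 to compound 3 (1.44 log units; beyond the scatter) and so outperforms the ring carried by compound 1. Nothing available here explains why this exchange has such a large effect.

Going by these compounds, it remains open whether the dimethyl groups on the sulfamoyl nitrogen are needed, or whether a plain sulfonamide or a methylsulfonyl group would serve as well. A nitrile or a carboxylic acid on this carbon would test how far the gain extends beyond sulfur-containing groups.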